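The source may report more compounds than this note shows. Statements on the series, on what has been measured and on what is new or still open speak of the compounds shown alone.

Measured compounds:
compound 1 `COC1Cc2c(cnn2-c2ccccc2)C2(CCN(Cc3ccco3)CC2)O1` — 2.2 nM
compound 2 `COC1Cc2c(cnn2-c2ccccc2)C2(CCN(CCCCc3ccccc3)CC2)O1` — 3.2 nM

Among the compounds with values here, in an assay for displacement of a labelled ligand from Sigma non-opioid intracellular receptor 1 (Cavia porcellus), read by scintillation counting, with a stated time of 180 min (a higher number here means a weaker inhibitor, a lower number a stronger inhibitor), compound 2 gives 3.2 nM, the higher of the two numbers; compound 1 gives 2.2 nM, and the only step, a 1.5-fold higher number from compound 1 to compound 2 (0.16 log units; within the scatter), lies within the scatter. Compound 3 `CCCN1CCC2(CC1)OC(OC)Cc1c2cnn1-c1ccccc1` differs from compound 2 by hydrogen in place of benzyl on a saturated chain carbon, three bonds along the chain from an amine nitrogen in a ring. Within the data shown here, that one measured step exchanges one aromatic end of the chain for another; no measured step removes the aromatic ring altogether, so it bears on this change only loosely. A higher number for compound 3 is expected, a 6.3-fold higher number from compound 2 to compound 3 (0.80 log units; beyond the scatter), though with wide uncertainty. Compound 3 is estimated at 20 nM, between 4 nM and 100 nM.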

Compound 3, inhibition constant: 33 nM
Beside the measured number, compound 3's estimate is 1.7-fold (0.22 log units) below it; the measured number falls inside the stated range.
By their numbers in this assay, from the lowest: compounds 1 and 2 (each within the scatter of the next); then compound 3.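

In this assay, 4-phenylbutyl to propyl gives a 10-fold higher number from compound 2 to compound 3 (1.01 log units; beyond the scatter), and ethyl in place of furan-2-yl gives a 15-fold higher number from compound 1 to compound 3 (1.18 log units; beyond the scatter). Among these compounds, the aromatic end of the chain therefore counts for far more than the earlier exchange of one aromatic end for another suggested. No measured evidence explains this loss. Still open, as far as these compounds go, is whether the aromatic ring itself is needed: a cyclohexyl end would test that. A longer plain alkyl chain would show whether chain length alone recovers the lost strength.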